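The source may report more compounds than this note shows. Statements on the series, on what has been measured and on what is new or still open speak of the compounds shown alone.

Measured so far in a functional assay on ECV-304 cells (Homo sapiens) for cytotoxicity, read by MTT assay, with stated times of 24 h and 12 h; on this read-out higher numbers stand for an effect only at larger amounts of compound and lower numbers for an effect already at smaller amounts:
- compound 1 `CCOC(=O)/C=C/c1cccc(OCc2nc(C)c(C)nc2C)c1` gives 4330000 nM in this test
- compound 2 `CCOC(=O)/C=C/c1cc(Br)c(OCc2nc(C)c(C)nc2C)c(Br)c1` gives 155000 nM in this test

Of these two numbers, compound 2 at 155000 nM holds the lower one, and the gap up to compound 1 lies beyond the scatter. Compound 3 `Cc1nc(C)c(COc2c(Br)cc(/C=C/C(=O)O)cc2Br)nc1C` is still to be measured. It differs from compound 2 by one change hydrogen in place of ethyl on an oxygen next to a carbonyl group in which hydrogen stands in place of ethyl on an oxygen next to a carbonyl group, so that ethoxycarbonyl becomes carboxy. Among the measured compounds shown here, no pair of measured compounds shows what this change does in this assay and the data offer no direct guide to its size or direction. The expectation is therefore modest, with no step beyond the scatter. The expected outcome is a 1.6-fold lower number from compound 2 to compound 3 (0.19 log units; within the scatter) and this estimated step stays within the scatter. The range is kept wide, as the two measured values already lie well apart in this small set, with compound 2 at 155000 nM and compound 1 at 4330000 nM. For compound 3 the expected value is 100000 nM with an estimated range of 8000 nM to 1200000 nM as the likely span.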

Compound 3, half-maximal effective concentration: 3280000 nM
Estimate against measurement, compound 3: 33-fold (1.52 log units) below, and the stated range ends below it.
By their numbers in this assay, from the lowest: compound 2; then compounds 3 and 1 (each within the scatter of the next).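

In this assay, among the compounds shown here, the exchange of ethyl for hydrogen on an oxygen next to a carbonyl group, which turns ethoxycarbonyl into carboxy, gives a 21-fold higher number from compound 2 to compound 3 (1.33 log units; beyond the scatter) and is the first step in this set that can be read between compounds differing in one place. It shows that this end of the chain is not a silent position, since going from 2-(ethoxycarbonyl)ethenyl to 2-carboxyethenyl with the rest of compound 2 unchanged moves the number towards an effect only at larger amounts of compound. Nothing shown here accounts for the size or direction of this step.

The compounds shown leave open whether an amide or a longer ester such as a propyl ester in the same place would stay close to compound 2 or move as compound 3 does. They also leave open whether carboxy in place of ethoxycarbonyl on the core of compound 1, which carries hydrogen where compound 2 carries bromine, would bring a step of similar size or none at all.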